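Exchanging Ethyl for Bromophenyl on the Amide Carbonyl

This account rests on a few compounds, and the source may have more. Where it says the series, first, only, none or still open, it means among the compounds named here.

Three compounds sharing one core were measured in a functional assay on A549 cells (Homo sapiens) for antiproliferative activity, read by MTT assay, with a stated time of 72 h; a higher number here means a weaker inhibitor, a lower number a stronger inhibitor:
compound 1 `CCC(=O)N(C)c1ccc2[nH]c(-c3n[nH]c4ccccc34)cc2n1` gives 15700 nM;
compound 2 `CN(C(=O)C(C)(C)C)c1ccc2[nH]c(-c3n[nH]c4ccccc34)cc2n1` gives 24400 nM;
compound 3 `CN(C(=O)c1ccc(Cl)cc1)c1ccc2[nH]c(-c3n[nH]c4ccccc34)cc2n1` gives 2220 nM.

Compound 1 stands second highest of these three numbers. One step reads a 1.6-fold higher number from compound 1 to compound 2 (0.19 log units; within the scatter), which lies within the scatter. The other reads a 7.1-fold lower number from compound 1 to compound 3 (0.85 log units; beyond the scatter), beyond the scatter, and a similar step is an 11-fold lower number from compound 2 to compound 3 (1.04 log units; beyond the scatter).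

Compound 4 `CN(C(=O)c1ccc(Br)cc1)c1ccc2[nH]c(-c3n[nH]c4ccccc34)cc2n1` differs from compound 1 in one place: 4-bromophenyl in place of ethyl on a carbonyl carbon. For the measured compounds named here, the steps that bear on this are a 7.1-fold lower number from compound 1 to compound 3 (0.85 log units; beyond the scatter) and an 11-fold lower number from compound 2 to compound 3 (1.04 log units; beyond the scatter), both putting an aryl group on the carbonyl carbon. A 4-bromophenyl is expected to act much like a 4-chlorophenyl here, so the step expected is a 7.1-fold lower number from compound 1 to compound 4 (0.85 log units; beyond the scatter). Compound 4 is therefore estimated at 2200 nM, with a range from 800 nM to 6000 nM.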

Compound 4, half-maximal inhibitory concentration: 4250 nM
For compound 4 the middle estimate is 1.9-fold (0.29 log units) below the measured one, within the range that was stated.
By their numbers in this assay, from the lowest: compounds 3 and 4 (each within the scatter of the next); then compounds 1 and 2 (each within the scatter of the next).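

In this assay the gain on the carbonyl carbon is not tied to 4-chlorophenyl alone: 4-bromophenyl also improves on ethyl and tert-butyl, with a 3.7-fold lower number from compound 1 to compound 4 (0.57 log units; beyond the scatter) and a 5.7-fold lower number from compound 2 to compound 4 (0.76 log units; beyond the scatter) in this set. With a 1.9-fold higher number from compound 3 to compound 4 (0.28 log units; within the scatter) the two halogens cannot be told apart here. Nothing available explains why these aryl groups do better than ethyl or tert-butyl.

As far as these compounds go, it remains open how a plain phenyl, a 4-fluorophenyl or a 4-methoxyphenyl on the carbonyl carbon would compare. From the compounds shown here alone, a phenyl ring carrying an amine or a carboxylic acid is equally open.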